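Swapping the ethoxy group for a pyrimidinylamino group

This account rests on a few compounds, and the source may have more. Where it says the series, first, only, none or still open, it means among the compounds named here.

Of the compounds shown here, two sharing one core have been measured. Compound 1 `Cc1cc(SC(C)(C)C)c(S(C)(=O)=O)cc1C(=O)N=C(N)N` carries a (tert-butyl)sulfanyl group and in a functional assay for inhibition of sodium/hydrogen exchanger (Oryctolagus cuniculus) (a lower number here means a stronger inhibitor, a higher number a weaker inhibitor), compound 1 gives 22 nM. Compound 2 `CCOc1cc(C)c(C(=O)N=C(N)N)cc1S(C)(=O)=O` carries an ethoxy group in its place, and in this assay compound 2 gives 19 nM. The step from compound 1 to compound 2 is a 1.2-fold lower number from compound 1 to compound 2 (0.06 log units; within the scatter), so the two compounds cannot be told apart on these numbers. Compound 2 thus stands with the lower of the two numbers, but only within the scatter of compound 1.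

Compound 3 `Cc1cc(Nc2ncccn2)c(S(C)(=O)=O)cc1C(=O)N=C(N)N` is not yet measured. It differs from compound 2 in one place: (pyrimidin-2-yl)amino in place of ethoxy on an aromatic carbon. For the measured compounds named here, the only measured step at this position, from compound 1 to compound 2, was within the scatter, which suggests the core tolerates exchange of this group, though the new group is larger and brings a hydrogen-bond donor, which the two measured compounds do not test. In this assay compound 3 is therefore expected to give roughly 30 nM, with a range from 8 nM to 120 nM. The expected step is a 1.6-fold higher number from compound 2 to compound 3 (0.20 log units; within the scatter), with no clear direction beyond the scatter.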

Compound 3, half-maximal inhibitory concentration: 8.3 nM
Beside the measured number, compound 3's estimate is 3.6-fold (0.56 log units) above it, within the range that was stated.
By their numbers in this assay, from the lowest: compound 3; then compounds 2 and 1 (each within the scatter of the next).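

In this assay this position now shows a change beyond the scatter: (pyrimidin-2-yl)amino in place of ethoxy gives a 2.3-fold lower number from compound 2 to compound 3 (0.36 log units; beyond the scatter), and the same group in place of (tert-butyl)sulfanyl gives a 2.7-fold lower number from compound 1 to compound 3 (0.42 log units; beyond the scatter). The two earlier groups could not be told apart, so the position might have seemed indifferent to what it carries, but this modest shift shows that the number can move with the group on this aromatic carbon, ortho to the methylsulfonyl group. No measurement available here speaks to what lies behind the lower number.

The entering group differs from ethoxy in several ways at once, bringing a six-membered aromatic ring, a hydrogen-bond donor and more hydrogen-bond acceptors, so the compounds shown cannot say which of these features matters. Going by these compounds, a plain methylamino group would test the nitrogen link without the ring, while a phenylamino group would keep the link and carry a ring of carbon only, and how either compares with compound 3 remains open.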